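The compounds below may be only part of what the source reports. "The series", "measured", "known", "first", "only" and "open" are said of these compounds alone.

In a functional assay on HCT-116 cells (Homo sapiens) for antiproliferative activity, read by MTT assay, with a stated time of 48 h (on this read-out lower numbers stand for stronger inhibition and higher numbers for weaker inhibition), compound 2 `Cc1c(C(=O)NCCS(C)(=O)=O)oc2ccc(N(Cc3ccc(Br)cc3)S(=O)(=O)c3ccc(Br)cc3)cc12` gives only a limit of the assay, > 40000 nM. That reading is a limit, the one at which one of the two measured values sits (the limit of > 40000 nM in this assay, at which 1 of the 2 values shown sits). Compound 1 `Cc1c(C(=O)NCCCN(C)C)oc2ccc(N(Cc3ccc(Br)cc3)S(=O)(=O)c3ccc(Br)cc3)cc12` carries a (dimethylamino)methyl group on the saturated chain where compound 2 carries methylsulfonyl, and in this assay compound 1 gives 3730 nM. Among the compounds with values here, the single measured step, an at least 10-fold higher number from compound 1 to compound 2 (1.03 log units; beyond the scatter), concerns exactly the group that is about to leave. Compound 3 `Cc1ccc(NC(=O)c2oc3ccc(N(Cc4ccc(Br)cc4)S(=O)(=O)c4ccc(Br)cc4)cc3c2C)nc1` has not been measured; it differs from compound 2 by 5-methylpyridin-2-yl in place of 2-(methylsulfonyl)ethyl on an amide-type nitrogen. The methylsulfonyl chain that went with that large loss departs, and a 5-methylpyridin-2-yl group takes its place on the amide-type nitrogen. A step toward a lower number is therefore expected in this assay, an at least 6.6-fold lower number from compound 2 to compound 3 (0.82 log units; beyond the scatter), though its size is uncertain. Compound 3 is estimated at 6000 nM, in a range from 1200 nM to 40000 nM.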

Compound 3, half-maximal inhibitory concentration: > 40000 nM
Compound 3: only a limit was reported (the forecaster's own chance of this, stated with the estimate: 30%); middle value at least 6.6-fold (0.82 log units) away from the limit.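

In this assay, 5-methylpyridin-2-yl on the amide-type nitrogen in place of 3-(dimethylamino)propyl gives an at least 10-fold higher number from compound 1 to compound 3 (1.03 log units; beyond the scatter), so this aromatic ring goes with a large step in the same direction as the 2-(methylsulfonyl)ethyl chain. The step between the two compounds that sit at the limit cannot be read, so the two groups cannot be ranked against each other. Of the three groups shown at this place, only the 3-(dimethylamino)propyl group of compound 1 gives a number rather than a limit of the assay: the limit of > 40000 nM in this assay, at which 2 of the 3 values shown sit.

The compounds shown leave open whether the dimethylamino group itself or the length of the chain carrying it goes with the measurable value. A 2-(dimethylamino)ethyl chain, a longer 4-(dimethylamino)butyl chain or a primary amine on the same propyl chain would each test a part of that question.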